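The compounds below may be only part of what the source reports. "The series", "measured", "known", "first", "only" and "open" are said of these compounds alone.

Measured so far:
- compound 1 `Cc1ccc(S(=O)(=O)/C(=C/c2c(F)c(F)c(F)c(F)c2F)C(=O)c2ccc(Cl)cc2)cc1`: > 100000 nM
- compound 2 `Cc1ccc(S/C(=C/c2c[nH]c3ccc(Cl)cc23)C(=O)c2ccc(Cl)cc2)cc1`: 1000 nM

In a functional assay on DU-145 cells (Homo sapiens) for inhibition, read by trypan blue exclusion, with a stated time of 96 h (on this read-out lower numbers stand for stronger inhibition of growth and higher numbers for weaker inhibition of growth), compound 1 gives > 100000 nM, which is a limit of the assay and not a number. Compound 3 `Cc1ccc(S/C(=C/c2c(F)c(F)c(F)c(F)c2F)C(=O)c2ccc(Cl)cc2)cc1` has (4-methylphenyl)sulfanyl in place of (4-methylphenyl)sulfonyl on a double-bonded chain carbon bound to a carbonyl carbon and a double-bonded chain carbon. Going by the values given here, no measured pair isolates this change. Among the compounds with values here, the only pointer is compound 2, which also carries (4-methylphenyl)sulfanyl and gives 1000 nM, but it differs from compound 3 elsewhere as well. A move towards stronger inhibition of growth in this assay is therefore expected, though with low confidence. The expected step is an at least 10-fold lower number from compound 1 to compound 3 (1.00 log units; beyond the scatter). For compound 3 the estimated value is 10000 nM, with an expected range from 1000 nM to 100000 nM.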

Compound 3, concentration for 50% growth inhibition: 25000 nM
Estimate against measurement, compound 3: 2.5-fold (0.40 log units) below; measured number inside the range.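

In this assay, going by these compounds alone, the first readable step at this position comes from (4-methylphenyl)sulfanyl in place of (4-methylphenyl)sulfonyl on a double-bonded chain carbon bound to a carbonyl carbon and a double-bonded chain carbon: the change gives an at least 4.0-fold lower number from compound 1 to compound 3 (0.60 log units; beyond the scatter) on the shared core. Compound 1 gives > 100000 nM and this is a limit of the assay, not a number. The full size of the step therefore stays unknown, and only its lower bound can be read, for this reason: the limit of > 100000 nM in this assay, at which 1 of the 3 values shown sits.

Open, on these data alone, is how a (4-methylphenyl)sulfinyl group, or a plain ether oxygen carrying the same 4-methylphenyl ring, would read at this place. Also open, as far as these compounds go, is whether the same change gives a step of similar size on the core of compound 2.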